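Two Amide Caps at the Assay Limit, a Thiazole Next

The source may report more compounds than this note shows. Statements on the series, on what has been measured and on what is new or still open speak of the compounds shown alone.

Compound 1 `C=CC(=O)Nc1cccc(-c2nc3ccccc3s2)c1` carries a vinyl group on the carbonyl carbon of its amide. In an ADME assay on HepG2 cells (Homo sapiens) for inhibition, with a stated time of 72 h (a higher number here means that more compound is needed for the effect, a lower number that less compound is needed), compound 1 gives > 25000 nM, which is a limit of the assay rather than a number. Compound 2 `O=C(Nc1cccc(-c2nc3ccccc3s2)c1)c1ccc(Cl)nc1Cl` instead bears a 2,6-dichloropyridin-3-yl on that carbonyl carbon. In this assay compound 2 gives > 25000 nM, again a limit and not a number. The step that the two limits leave unreadable from compound 1 to compound 2 therefore cannot be read, since both values sit at the limit of > 25000 nM in this assay, at which 2 of the 2 values shown sit. Compound 3 `O=C(Nc1cccc(-c2nc3ccccc3s2)c1)c1cnc(Cl)s1` differs from compound 2 by 2-chloro-1,3-thiazol-5-yl in place of 2,6-dichloropyridin-3-yl on a carbonyl carbon. For the measured compounds named here, the single measured step bears on this change only by showing that two quite different amide caps both leave the value at the limit; no readable step supports any expectation of movement in this assay. The estimate for compound 3 is 30000 nM, with a range from 10000 nM to 90000 nM. The expected step that the limit leaves unreadable from compound 2 to compound 3 is thus no more than scatter, with a limit again the most likely outcome.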

Compound 3, half-maximal effective concentration: > 25000 nM
Compound 3 was reported as a limit; the forecaster's own chance of this, stated with the estimate: 80%; the middle value is on the limit's open side.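

In this assay compound 3 gives > 25000 nM, again a limit and not a number. The steps among compound 1, compound 2 and compound 3 therefore cannot be read: the limit of > 25000 nM in this assay, at which 3 of the 3 values shown sit. As far as these compounds go, whether any amide cap on the shared core gives a readable number stays open.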